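The compounds below may be only part of what the source reports. "The series", "measured", "known", "first", "only" and "open" are said of these compounds alone.

Two compounds share the same core and are drawn here: compound 1 `CNC(=O)c1cc(Oc2ccc(/C=C/C(=O)c3ccc(C)cc3)cc2)ccn1` and compound 2 `CNC(=O)c1cc(Oc2ccc(C(=O)/C=C/c3cccc(Br)c3)cc2)ccn1`. In a functional assay on PC-3 cells (Homo sapiens) for cytotoxicity, read by MTT assay, with a stated time of 72 h (a lower number here means a stronger inhibitor, a higher number a weaker inhibitor), compound 1 gives "not determined" (no result reported), so no result for it is available. In this assay compound 2 gives 3400 nM, and this is the only number shown among the compounds so far, so compound 2 stands alone as the reference point rather than at the top or bottom of any ranking. Compound 3 `CNC(=O)c1cc(Oc2ccc(C(=O)/C=C/c3cccc(Cl)c3Cl)cc2)ccn1` is the next compound to be measured in this assay. It differs from compound 2 in one place: 2,3-dichlorophenyl in place of 3-bromophenyl on a double-bonded chain carbon bound to a double-bonded chain carbon. Among the compounds with values here, no pair of measured compounds differing in a single place is available, so the size of this step cannot be read from earlier data. Within the data shown here, with only one measured value to rest on, the step from compound 2 to compound 3 is expected to stay within the usual scatter, with no clear direction; as an estimate it is a 1.1-fold lower number from compound 2 to compound 3 (0.05 log units; within the scatter). Compound 3 is therefore estimated at 3000 nM, in a range from 1200 nM to 8000 nM.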

Compound 3, half-maximal inhibitory concentration: > 50000 nM
Compound 3 gave a limit, no number; the forecaster's own chance of this, stated with the estimate: 10%; at least 16-fold (1.22 log units) between middle value and limit.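

Within the data shown here, the first readable step at this position shows that the ring on the double-bonded chain carbon cannot be swapped freely: in this assay, 2,3-dichlorophenyl in place of 3-bromophenyl gives an at least 14-fold higher number from compound 2 to compound 3 (1.16 log units; beyond the scatter). The value of compound 3 is a limit, not a number: the limit of > 50000 nM in this assay, at which 1 of the 3 values shown sits. A change confined to this one aromatic ring, with no hydrogen-bond donors or acceptors entering or leaving, is therefore enough to move the result beyond the scatter.

This single step removes one bromine and brings in two chlorines, so it cannot show which part of the change matters, and compound 1 adds no comparison because it has no result. On these data alone, it also remains open whether 3-chlorophenyl, or a phenyl ring carrying an amine or a methoxy group, would read closer to compound 2 or to compound 3.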